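Dihydropyridine aryl substituent: from methyl to hydroxyl

The source may report more compounds than this note shows. Statements on the series, on what has been measured and on what is new or still open speak of the compounds shown alone.

Of the compounds shown here, three of one shared core have been measured in a functional assay (muscle tissue) with Cavia porcellus as the target; a lower number here means that less compound is needed, a higher number that more compound is needed for the effect. Compound 1 `COC(=O)C1=C(C)N=C(C)/C(=C(\O)OC)C1c1cccc([N+](C)(C)C)c1` gives 50100 nM, compound 2 `COC(=O)C1=C(C)N=C(C)/C(=C(\O)OC)C1c1ccccc1C#N` gives 15.9 nM, and compound 3 `COC(=O)C1=C(C)N=C(C)/C(=C(\O)OC)C1c1ccccc1C` gives 6.03 nM. Compound 3 thus stands lowest of the three; its nearest neighbour is compound 2, while compound 1 lies far above it, with a value that shows the weakest effect of the set. For the measured compounds named here, the one measured step that changes the aromatic ring is a 2.6-fold lower number from compound 2 to compound 3 (0.42 log units; beyond the scatter).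

Compound 4 `COC(=O)C1=C(C)N=C(C)/C(=C(\O)OC)C1c1cccc(O)c1` has not yet been measured. Relative to compound 3 it differs as follows: 3-hydroxyphenyl in place of 2-methylphenyl on a saturated ring carbon. Going by the values given here, no measured step exchanges a 2-methylphenyl for a 3-hydroxyphenyl, so the step from compound 2 to compound 3 bears on it only loosely, as a sign that a change on the aromatic ring can move this assay beyond the scatter. Among the compounds with values here, compound 1 shows that a group on that ring can also push the number very far up, though no step to it is computed. On this evidence the step is expected to go upward, a 50-fold higher number from compound 3 to compound 4 (1.70 log units; beyond the scatter), with wide uncertainty. Compound 4 is therefore estimated at 300 nM, within a range from 40 nM to 2500 nM.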

Compound 4, half-maximal effective concentration: 1000 nM
Compound 4: middle estimate off by 3.3-fold (0.52 log units), on the low side; measured number inside the range.
By their numbers in this assay, from the lowest: compound 3; then compound 2; then compound 4; then compound 1.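

In this assay, a 170-fold higher number from compound 3 to compound 4 (2.22 log units; beyond the scatter) shows that 3-hydroxyphenyl in place of 2-methylphenyl on the saturated ring carbon costs far more than the exchange of nitrile for methyl seen earlier, a 2.6-fold lower number from compound 2 to compound 3 (0.42 log units; beyond the scatter); the exchange for 2-cyanophenyl points the same way, with a 63-fold higher number from compound 2 to compound 4 (1.80 log units; beyond the scatter). At the aromatic carbon that compound 1 and compound 4 share, one oxygen atom in place of the group of 4 heavy atoms gives a 50-fold lower number from compound 1 to compound 4 (1.70 log units; beyond the scatter), so the number at this carbon varies widely with the group, yet both compounds stand above compound 2 and compound 3. Nothing given here explains the size of these steps.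

Compound 4 differs from compound 2 and compound 3 in both the group and where it sits on the aromatic ring, so these compounds cannot separate the effect of the hydroxyl from that of its place. They also leave open how a methoxy group, an amine or a carboxylic acid at that same aromatic carbon would compare, and whether 2-hydroxyphenyl would return the number towards that of compound 3.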